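The source may report more compounds than this note shows. Statements on the series, on what has been measured and on what is new or still open speak of the compounds shown alone.

Of the compounds shown here, three built on a shared core have been measured in an assay on HEK293 cells for negative allosteric modulation of metabotropic glutamate receptor 5 (Homo sapiens), read by FLIPR; a higher number here means a weaker inhibitor, a lower number a stronger inhibitor. Compound 1 `O=C(c1ccc(F)c(F)c1)N1CC(c2nc(-c3cccc(F)c3)no2)C1` gives only > 10000 nM, which is a limit of the test rather than a number (the limit of > 10000 nM in this assay, at which 1 of the 3 values shown sits). Compound 2 `O=C(c1ccc(F)cc1)N1CC(c2nc(-c3cccc(Cl)c3)no2)C1` gives 4000 nM, the higher of the two numbers recorded in this assay, while compound 3 `O=S(=O)(c1ccc(Cl)cc1)N1CC(c2nc(-c3cccc(Cl)c3)no2)C1` gives 170 nM, a lower value that lies beyond the usual scatter. Compound 4 `CC1CCN(C(=O)N2CC(c3nc(-c4cccc(Cl)c4)no3)C2)CC1` has not yet been measured; it differs from compound 2 by 4-methylpiperidin-1-yl in place of 4-fluorophenyl on a carbonyl carbon, a 4-methylpiperidin-1-yl in place of 4-fluorophenyl on a carbonyl carbon. Among the measured compounds shown here, no measured pair shows this kind of change, so the step from compound 2 to compound 4 is expected to be modest, estimated at a 1.6-fold lower number from compound 2 to compound 4 (0.20 log units; within the scatter), and it may fall within the scatter. Compound 4 is therefore expected to give about 2500 nM, between 600 nM and 10000 nM.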

Compound 4, half-maximal inhibitory concentration: > 10000 nM
Compound 4 gave a limit, no number; the forecaster's own chance of this, stated with the estimate: 25%; at least 4.0-fold (0.60 log units) between middle value and limit.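

On this carbonyl carbon, 4-methylpiperidin-1-yl in place of 4-fluorophenyl gives an at least 2.5-fold higher number from compound 2 to compound 4 (0.39 log units; beyond the scatter), so a six-membered non-aromatic ring with the same number of heavy atoms does not keep the activity of compound 2. Compound 4 gives only a limit, not a number, so the full size of this loss cannot be read: the limit of > 10000 nM in this assay, at which 2 of the 4 values shown sit.

On these data alone, it remains open whether any non-aromatic group can work on this carbonyl carbon. A cyclohexyl ring, a morpholine or a small dimethylamino group there would help show whether the ring nitrogen or the loss of the aromatic ring matters more.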